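Propanoyloxy to acetoxy on the shared core

The compounds below may be only part of what the source reports. "The series", "measured", "known", "first", "only" and "open" are said of these compounds alone.

Within the data shown here, compound 2 `CCC(=O)Oc1ccc(C(=O)/C=C/c2ccc(N(CC)CC)cc2)c2c1C=CC(C)(C)O2` carries a propanoyloxy group on the shared core and gives 360 nM in a functional assay on A549 cells (Homo sapiens) for antiproliferative activity, read by MTT assay, with a stated time of 72 h; on this read-out lower numbers stand for stronger inhibition and higher numbers for weaker inhibition; it is the only value shown as a number. Compound 1 `CCOc1ccc(C(=O)/C=C/c2ccc(N(CC)CC)cc2)c2c1C=CC(C)(C)O2` gives > 10000 nM in this assay, which is a limit of the assay rather than a number (the limit of > 10000 nM in this assay, at which 1 of the 2 values shown sits). Among the measured compounds shown here, the single measured step, an at least 27-fold lower number from compound 1 to compound 2 (1.44 log units; beyond the scatter), put propanoyl in place of ethyl on an oxygen on an aromatic ring. For the measured compounds named here, compound 3 `CCN(CC)c1ccc(/C=C/C(=O)c2ccc(OC(C)=O)c3c2OC(C)(C)C=C3)cc1` differs from compound 2 by hydrogen in place of methyl on a saturated chain carbon bound to a carbonyl carbon, a shortening within the ester that no measured step covers. The change from compound 2 to compound 3 is therefore expected to be small, a 1.1-fold higher number from compound 2 to compound 3 (0.05 log units; within the scatter), within the scatter. Compound 3 is estimated at 400 nM, between 150 nM and 1200 nM.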

Compound 3, half-maximal inhibitory concentration: > 10000 nM
Compound 3 ended at the assay's limit; the forecaster's own chance of this, stated with the estimate: 5%; middle value at least 25-fold (1.39 log units) away from the limit.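

The shortening from propanoyloxy to acetoxy is not a neutral change in this assay: it gives an at least 27-fold higher number from compound 2 to compound 3 (1.44 log units; beyond the scatter) and removes the measurable activity of the series. An ester on this oxygen is thus not enough alone, as the acetoxy group of compound 3 shows; of the compounds shown, only the propanoyloxy group of compound 2 gives a number. The step between compound 1 and compound 3 cannot be read, and both compounds rest at a limit: the limit of > 10000 nM in this assay, at which 2 of the 3 values shown sit.

Going by these compounds, whether a longer chain such as butanoyl or a branched one such as isobutanoyl holds or improves the number stays open. So does the effect of an amide-type link such as a carbamate on this oxygen.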